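From hex-1-en-1-yl to hex-1-yn-1-yl at the assay limit

This account rests on a few compounds, and the source may have more. Where it says the series, first, only, none or still open, it means among the compounds named here.

In an ADME assay on L1210/0 cells (Mus musculus) for cytotoxicity, with a stated time of 48 h (a lower number here means a stronger inhibitor, a higher number a weaker inhibitor), compound 3 (`CCCC/C=C\c1cn([C@H]2C[C@H](O)[C@@H](CO)O2)c(=O)[nH]c1=O`) gives > 200000 nM as a limit of the assay, not a number. Compound 2 (`N#Cc1cn([C@H]2C[C@H](O)[C@@H](CO)O2)c(=O)[nH]c1=O`) gives > 200000 nM as a limit too. Compound 1 (`N#CSc1cn([C@H]2C[C@H](O)[C@@H](CO)O2)c(=O)[nH]c1=O`) alone gives 78900 nM as a measured number. The nearest measured steps are an at least 2.5-fold higher number from compound 1 to compound 3 (0.40 log units; beyond the scatter) and an at least 2.5-fold higher number from compound 1 to compound 2 (0.40 log units; beyond the scatter) as well as one more (a step that the two limits leave unreadable from compound 2 to compound 3). Compound 4 (`CCCCC#Cc1cn([C@H]2C[C@H](O)[C@@H](CO)O2)c(=O)[nH]c1=O`) carries hex-1-yn-1-yl in place of hex-1-en-1-yl on an aromatic carbon. For the measured compounds named here, no measured step exchanges these two groups. Compound 3 offers only the limit of > 200000 nM in this assay, at which 2 of the 3 values shown sit, as its reference. In this assay only a small step is expected (an at least 1.2-fold lower number from compound 3 to compound 4 (0.09 log units; that floor lies within the scatter)). The estimated value for compound 4 is 160000 nM (expected range 50000 nM to 300000 nM).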

Compound 4, half-maximal inhibitory concentration: > 200000 nM
Compound 4: a limit, no number (the forecaster's own chance of this, stated with the estimate: 55%); middle value at least 1.2-fold (0.09 log units) away from the limit.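

In this assay compound 4 gives only a limit of the assay, so hex-1-yn-1-yl joins hex-1-en-1-yl and cyano as a group at this position without a measured number. The one readable step is an at least 2.5-fold higher number from compound 1 to compound 4 (0.40 log units; beyond the scatter), which leaves cyanosulfanyl as the only group shown here with a number. The steps among compound 2, compound 3 and compound 4 cannot be read, because all three stop at the same ceiling: the limit of > 200000 nM in this assay, at which 3 of the 4 values shown sit.

From the compounds shown here alone, how far compound 2, compound 3 and compound 4 differ from one another remains open. Also open, going by these compounds, is whether a longer chain or an amine at this position would give a measured number.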